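A few compounds are considered here, and "the series" means these few. Any claim that something is new, unique, unknown or untested is made for them only; others in the source may bear on it.

Compound 3 `COc1cccc(Cc2nn3cc(-c4cccc(N)c4)nc3s2)c1` stands second highest of the three numbers in a functional assay on HeLa cells (Homo sapiens) for inhibition, read by cell counting, with a stated time of 4 days; on this read-out lower numbers stand for stronger inhibition and higher numbers for weaker inhibition: compound 3 gives 24000 nM, compound 2 `Nc1cccc(-c2cn3nc(Cc4ccc(Cl)cc4)sc3n2)c1` gives 25000 nM, and compound 1 `C=C(Br)C(=O)Nc1cccc(-c2cn3nc(CCc4ccccc4)sc3n2)c1` gives 3300 nM. The change to compound 4 `Nc1cccc(-c2cn3nc(CCc4ccccc4)sc3n2)c1` is benzyl in place of 3-methoxyphenyl on a saturated chain carbon bound to an aromatic carbon. Within the data shown here, the one step that bears on it, a change of the aryl on the same chain carbon, is a 1.0-fold lower number from compound 2 to compound 3 (0.02 log units; within the scatter), so swapping that aryl has so far left this assay unchanged. Among the measured compounds shown here, compound 1 shares the benzyl that enters but differs at another place, and no step between compound 1 and compound 4 is computed. No step beyond the scatter is therefore expected; the estimate implies no change at the digits printed from compound 3 to compound 4 (within the scatter). Compound 4 is expected at 24000 nM, ranging from 10000 nM to 55000 nM.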

Compound 4, half-maximal inhibitory concentration: 242000 nM
Compound 4: middle estimate off by 10-fold (1.00 log units), on the low side; measured number outside the range, above it.
By their numbers in this assay, from the lowest: compound 1; then compounds 3 and 2 (each within the scatter of the next); then compound 4.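

In this assay, the group on a saturated chain carbon bound to an aromatic carbon does matter: benzyl in place of 3-methoxyphenyl gives a 10-fold higher number from compound 3 to compound 4 (1.00 log units; beyond the scatter) and benzyl in place of 4-chlorophenyl gives a 9.7-fold higher number from compound 2 to compound 4 (0.99 log units; beyond the scatter), although the two aryl groups themselves did not separate. On a nitrogen on an aromatic ring, hydrogen in place of (1-bromoethenyl)carbonyl gives a 73-fold higher number from compound 1 to compound 4 (1.87 log units; beyond the scatter), the largest step in the series. Nothing on hand accounts for either change.

Going by these compounds, whether benzyl differs through its chain or through the missing ring substituents stays open; phenyl on the same chain carbon would separate the two. Also open, on these data alone, is whether (1-bromoethenyl)carbonyl on that nitrogen lowers the number with 4-chlorophenyl or 3-methoxyphenyl in place.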